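The source may hold more compounds than are shown below. What is called first, only, known or untested is meant among the compounds shown, and "the series" means these compounds.

Compound 1, with the structure `O=c1[nH]cnc2c1c(-c1cccs1)cn2[C@@H]1O[C@H](CO)[C@@H](O)[C@H]1O`, is one of two compounds for which numbers exist here. In an ADME assay on BJ cells (Homo sapiens), read by MTT assay, with a stated time of 72 h (on this read-out higher numbers stand for weaker inhibition and lower numbers for stronger inhibition), compound 1 gives > 100000 nM, which is a limit of the assay and not a number. Its partner, compound 2, with the structure `Nc1nc2c(c(-c3cccs3)cn2[C@@H]2O[C@H](CO)[C@@H](O)[C@H]2O)c(=O)[nH]1`, carries an amino in place of hydrogen on an aromatic carbon. In this assay compound 2 gives > 100000 nM, likewise a limit. The step that the two limits leave unreadable from compound 1 to compound 2 therefore cannot be sized from these two values.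

The compound under study, compound 3, with the structure `O=c1[nH]cnc2c1c(-c1cc3ccccc3o1)cn2[C@@H]1O[C@H](CO)[C@@H](O)[C@H]1O`, differs from compound 1 by 1-benzofuran-2-yl in place of thiophen-2-yl on an aromatic carbon. No measured step touches the thiophen-2-yl group, so nothing shown bears directly on this change. What the data do show is that (the limit of > 100000 nM in this assay, at which 2 of the 2 values shown sit), which gives no sign of inhibition reaching the measurable window. On that footing compound 3 is expected to remain at or near the limit, with an expected step of a number no higher from compound 1 to compound 3 (the limit leaves the size open). The estimate for compound 3 in this assay is accordingly 100000 nM, within a range from 30000 nM to 300000 nM.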

Compound 3, half-maximal inhibitory concentration: 62700 nM
Compound 3: middle estimate off by 1.6-fold (0.20 log units), on the high side; the range from low to high includes it.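

Placing 1-benzofuran-2-yl in place of thiophen-2-yl on this aromatic carbon gives the first reading in this assay that is a number and not a limit, something compound 1 and compound 2 could not show. The change amounts to an at least 1.5-fold lower number from compound 1 to compound 3 (0.20 log units; that floor lies within the scatter), so the step has a floor but no measured size, and the data do not establish a real shift at this position. Compound 3 is thus the only compound shown with a readable value, while the other two stay at a limit: the limit of > 100000 nM in this assay, at which 2 of the 3 values shown sit.

The compounds shown do not separate the two things this change does at once, since it replaces sulfur with oxygen in the five-membered aromatic ring and also adds a six-membered aromatic ring of carbon only; a furan-2-yl or a 1-benzothiophen-2-yl group at the same carbon would bear on that question. They also leave open whether a phenyl group there would give a number in this assay, and whether the amino group of compound 2, set on the core of compound 3, would alter the reading.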